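Methoxy for chloro on an aromatic carbon: an expectation

A few compounds are considered here, and "the series" means these few. Any claim that something is new, unique, unknown or untested is made for them only; others in the source may bear on it.

Compound 1 `COc1ccc2[nH]c(-c3nc(C)no3)cc2c1`: 16700 nM
Compound 2 `COc1ccc2[nH]c(-c3nc(-c4ccc(Cl)cc4)no3)cc2c1`: > 50000 nM (a limit of the assay)

In a functional assay on MCF7 cells (Homo sapiens) for antiproliferative activity, read by WST assay, with a stated time of 72 h (on this read-out lower numbers stand for stronger inhibition and higher numbers for weaker inhibition), compound 1 gives 16700 nM. For compound 2 the reported value > 50000 nM is a limit of the assay rather than a number. Among the compounds with values here, compound 2 thus sits at the limit of > 50000 nM in this assay, at which 1 of the 2 values shown sits, and the single measured step, an at least 2.9-fold higher number from compound 1 to compound 2 (0.47 log units; beyond the scatter), describes the weakening that accompanies 4-chlorophenyl in place of methyl. Compound 3 `COc1ccc(-c2noc(-c3cc4cc(OC)ccc4[nH]3)n2)cc1` differs from compound 2 by methoxy in place of chloro on an aromatic carbon. Within the data shown here, no measured step addresses chloro against methoxy on that ring, so the only guide is that compound 2 already lies at the limit. On that basis compound 3 is expected to show no step beyond the scatter, a number no higher from compound 2 to compound 3 (the limit leaves the size open). The estimate for compound 3 in this assay is therefore 50000 nM, within a range of 15000 nM to 150000 nM.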

Compound 3, half-maximal inhibitory concentration: > 50000 nM
Compound 3 gave a limit, no number (the forecaster's own chance of this, stated with the estimate: 60%); the middle value sits exactly at the limit.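

In this assay compound 3 reads > 50000 nM and this is a limit of the assay, not a number. The step between the chloro and methoxy compounds cannot be read, so the two groups remain unranked at this position. Measured against the methyl group of compound 1, the 4-methoxyphenyl group gives an at least 2.9-fold higher number from compound 1 to compound 3 (0.47 log units; beyond the scatter) and so shows that the weakening seen with 4-chlorophenyl is not confined to the chloro group, with the limit now holding most of the values shown: the limit of > 50000 nM in this assay, at which 2 of the 3 values shown sit.

Going by these compounds, whether an amine or a carboxylic acid on that phenyl ring would bring the value back under the limit stays open. The same holds for a longer chain such as ethyl or propyl in place of the methyl of compound 1.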